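The source may hold more compounds than are shown below. What is called first, only, known or untested is meant among the compounds shown, and "the series" means these compounds.

Measured so far, in a functional assay on HCT-116 cells (Homo sapiens) for antiproliferative activity, read by MTT assay, with a stated time of 24 h; on this read-out higher numbers stand for weaker inhibition and lower numbers for stronger inhibition:

Compound 1 `COc1ccc(C(=O)/C=C/c2ccc(F)cc2)c2c1C=CC(C)(C)O2`: > 10000 nM, which is a limit of the assay.
Compound 2 `COc1ccc(C(=O)/C=C/c2cccc(C(F)(F)F)c2)c2c1C=CC(C)(C)O2`: 9710 nM.
Compound 3 `COc1ccc(C(=O)/C=C/c2ccco2)c2c1C=CC(C)(C)O2`: > 10000 nM, which is a limit of the assay.

The three compounds share one core and differ only in the aromatic ring that ends the double-bonded chain. Compound 3 gives no number in this assay, only a limit. Compound 1 likewise reaches only a limit. Compound 2 gives a number that lies close to that limit. The step that the two limits leave unreadable from compound 1 to compound 3 cannot be read, since the limit of > 10000 nM in this assay, at which 2 of the 3 values shown sit, covers both ends of it.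

Compound 4 `COc1ccc(C(=O)/C=C/c2cccc(O)c2)c2c1C=CC(C)(C)O2` is not yet measured. The change from compound 3 is 3-hydroxyphenyl in place of furan-2-yl on a double-bonded chain carbon bound to a double-bonded chain carbon. Among the compounds with values here, the only measured step that bears on this position, the one from 4-fluorophenyl to furan-2-yl, is of unknown size. Compound 1 and compound 2, which carry a six-membered carbon ring at this place, both sit at or near the limit, so a return to a six-membered carbon ring, now 3-hydroxyphenyl, is expected to leave compound 4 at about the same level. The expected step is a step that the limit leaves unreadable from compound 3 to compound 4, which is no more than the scatter. Compound 4 is therefore estimated at 12000 nM, within 4000 nM to 40000 nM, with a fair chance that again only a limit is reported.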

Compound 4, half-maximal inhibitory concentration: > 10000 nM
Compound 4: a limit, no number (the forecaster's own chance of this, stated with the estimate: 60%); the middle value is on the limit's open side.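

In this assay, compound 4 brings in 3-hydroxyphenyl, the only ring end shown that carries a hydrogen-bond donor, and its result is again a limit of the assay rather than a number. Hydroxy in place of trifluoromethyl on an aromatic carbon gives an at least 1.0-fold higher number from compound 2 to compound 4 (0.01 log units; that floor lies within the scatter), so no loss beyond the scatter can be claimed, although a larger loss is not ruled out. The steps to compound 4 from compound 1 and from compound 3 cannot be read, because both ends of each step sit at a limit: the limit of > 10000 nM in this assay, at which 3 of the 4 values shown sit.

Among the four compounds shown, only compound 2 gives a number, so it remains open how much the ring end at this place can change the activity in this assay. Going by these compounds, it also remains open whether an amine or a carboxylic acid on this ring, or a longer chain in place of the ring, would bring a value clearly inside the measurable range.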